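Octyl to pentyl: a chain-length step in the series

This account rests on a few compounds, and the source may have more. Where it says the series, first, only, none or still open, it means among the compounds named here.

Going by the values given here, compound 3 `CCCCCCCCc1cn(C(c2ccccc2)c2cc3cc(Br)ccc3nc2OC)nn1` gives 2.06% in an ADME assay on SK-OV-3 cells (Homo sapiens) for cytotoxicity, read by sulforhodamine B assay, with a stated time of 48 h, tested at 10 uM (a higher number here means more inhibition at the concentration tested (going by the name of the read-out), a lower number less inhibition), the lowest of the three numbers so far; compound 2 `COc1nc2ccc(Br)cc2cc1C(c1ccccc1)n1cc(-c2ccccc2F)nn1`, at 7.33%, lies within the scatter of it, while compound 1 `COc1nc2ccc(Br)cc2cc1C(c1ccccc1)n1cc(-c2ccc(Br)cc2)nn1`, at 13.4%, sits beyond it. Compound 4 `CCCCCc1cn(C(c2ccccc2)c2cc3cc(Br)ccc3nc2OC)nn1` differs from compound 3 by hydrogen in place of propyl on a saturated chain carbon, five bonds along the chain from an aromatic carbon. The measured steps all exchange the aryl group for another group: a number 11.3 percentage points lower from compound 1 to compound 3 (beyond the scatter), a number 5.3 percentage points lower from compound 2 to compound 3 (within the scatter) and a number 6.1 percentage points lower from compound 1 to compound 2 (within the scatter). Among the compounds with values here, none of them shortens the chain, so no step bears directly on this change. With compound 3 already near the floor of the read-out, the expected step of a number 0.9 percentage points higher from compound 3 to compound 4 (within the scatter) is none beyond the scatter. Compound 4 is therefore estimated at 3%, with a range of -5% to 12%.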

Compound 4, a percentage reported as inhibition, at one concentration (the size of the read-out at that concentration, not a potency): 10.5%
Compound 4: the middle estimate sits 7.5 percentage points below what was measured, within the range that was stated.
By their numbers in this assay, from the lowest: compounds 3, 2, 4 and 1 (each within the scatter of the next, the first and the last beyond it).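

In this assay, hydrogen in place of propyl, five bonds along the chain from an aromatic carbon, gives a number 8.4 percentage points higher from compound 3 to compound 4 (within the scatter), so this shortening of the chain does not separate the two compounds. Pentyl also stays close to both aryl groups, with a number 3.2 percentage points higher from compound 2 to compound 4 (within the scatter) and a number 2.9 percentage points lower from compound 1 to compound 4 (within the scatter), whereas octyl gave a number 11.3 percentage points lower from compound 1 to compound 3 (beyond the scatter). No measurement shown accounts for these numbers.

From the compounds shown here alone, whether a propyl chain, or a chain ending in an amine or a carboxylic acid, would move the number beyond the scatter of compound 3 remains open.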